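Chain-linked aryloxy acids: removal of a methyl near carboxyl

The source may hold more compounds than are shown below. What is called first, only, known or untested is meant among the compounds shown, and "the series" means these compounds.

Measured compounds:
compound 1 `Cc1cc(C(=O)O)ccc1OCCCCOc1ccc(C(=O)CC(C)C)c(O)c1C`: 42.1%
compound 2 `Cc1c(OCCCCOc2ccc(C(=O)O)cc2)ccc(C(=O)CC(C)C)c1O`: 51.9%
compound 3 `Cc1ccc(C(=O)O)cc1OCCCCOc1ccc(C(=O)CC(C)C)c(O)c1C`: 29.4%

All three were read in an assay on HEK293 cells for positive allosteric modulation of metabotropic glutamate receptor 3 (Rattus norvegicus), read by thallium flux, with a stated time of 2.5 min; on this read-out lower numbers stand for smaller maximal responses and higher numbers for larger maximal responses. Compound 2 differs from compound 1 by hydrogen in place of methyl on an aromatic carbon; the step was a number 9.8 percentage points higher from compound 1 to compound 2 (within the scatter). Compound 3 carries a different core, the difference being (5-carboxy-2-methylphenyl in place of 4-carboxy-2-methylphenyl on an oxygen on a saturated carbon); the step was a number 12.7 percentage points lower from compound 1 to compound 3 (beyond the scatter), and from compound 2 it was a number 22.5 percentage points lower from compound 2 to compound 3 (beyond the scatter). Compound 3 thus gives the lowest of the three numbers, with both gaps beyond the scatter.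

Compound 4 `Cc1c(OCCCCOc2cccc(C(=O)O)c2)ccc(C(=O)CC(C)C)c1O` is not yet measured. It differs from compound 3 by hydrogen in place of methyl on an aromatic carbon. This is the same kind of change as that from compound 1 to compound 2, but not the same: there the place was meta to a carboxy group, here it is para to a carboxy group. Going by the values given here, the step is expected to be a number 6.6 percentage points higher from compound 3 to compound 4 (within the scatter), resting on the single earlier example a number 9.8 percentage points higher from compound 1 to compound 2 (within the scatter), which stayed within the scatter, so only a small rise is anticipated. Compound 4 is estimated at 36%, between 22% and 52%.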

Compound 4, largest response reached (reported as percent of maximum), in percent of the reference or control that the assay uses: 69.9%
Compound 4: the middle estimate sits 33.9 percentage points below what was measured; the whole stated range lies below it.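

In this assay, hydrogen in place of methyl on an aromatic carbon does not carry over from one core to another with a fixed size: the same change on two cores in this assay, a number 9.8 percentage points higher (within the scatter) from compound 1 to compound 2 and a number 40.5 percentage points higher (beyond the scatter) from compound 3 to compound 4, 30.7 percentage points apart, beyond the scatter of two such steps. With the methyl para to a carboxy group the step was a number 40.5 percentage points higher from compound 3 to compound 4 (beyond the scatter), and the 3-carboxyphenyl group also compares well with the other two aryl groups, the steps being a number 18 percentage points higher from compound 2 to compound 4 (beyond the scatter) and a number 27.8 percentage points higher from compound 1 to compound 4 (beyond the scatter). These two pairs show that the size of the step depends on the core that carries the change, but they do not show why, and they give no rule for any core beyond these four compounds.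

As far as these compounds go, it remains open whether the high number for the 3-carboxyphenyl group would hold with a longer chain or a shorter chain between the two oxygens. Also open, from the compounds shown here alone, is how an amide or a tetrazole would read in place of the carboxylic acid on that ring.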